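A few compounds are considered here, and "the series" means these few. Any claim that something is new, unique, unknown or untested is made for them only; others in the source may bear on it.

Measured in an ADME assay on HOS cells (Homo sapiens) for cytotoxicity, read by luminescence and ATP content, with a stated time of 48 h; on this read-out lower numbers stand for higher toxicity in this test and higher numbers for lower toxicity in this test:
- compound 1 `COC(=O)CNc1c(C(=O)NCc2ccc(F)cc2F)c(=O)n(O)c2nc(OC)ccc12`: 12000 nM
- compound 2 `Nc1c(C(=O)NCc2ccc(F)cc2F)c(=O)n(O)c2ncc(CCCC3CCCCC3)cc12`: 27400 nM

Of these two, compound 2 stands highest with 27400 nM, and compound 1 lies lower by more than the usual scatter of repeated measurements. The two compounds differ in more than one place, so their gap cannot be tied to any single change.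

The next compound to be tested is compound 3 `CN(C)C(=O)CCc1cnc2c(c1)c(N)c(C(=O)NCc1ccc(F)cc1F)c(=O)n2O`. It carries dimethylcarbamoyl in place of cyclohexylmethyl on a saturated chain carbon, two bonds along the chain from an aromatic carbon. Read one bond further out, 3-cyclohexylpropyl gives way to 2-(dimethylcarbamoyl)ethyl.

Going by the values given here, no measured pair shows this change on its own, so the expectation in this assay is only a rough one. It starts from compound 2 at 27400 nM and leans slightly towards a higher number, with no step beyond the scatter as the likeliest outcome. The estimate amounts to a 1.5-fold higher number from compound 2 to compound 3 (0.16 log units; within the scatter). For compound 3 the expected half-maximal cytotoxic concentration is 40000 nM, with an estimated range of 12000 nM to 150000 nM.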

Compound 3, half-maximal cytotoxic concentration: > 250000 nM
Compound 3: no number, only a limit; the forecaster's own chance of this, stated with the estimate: 25%; at least 6.2-fold (0.79 log units) between middle value and limit.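

Going by these compounds alone, compound 1 and compound 2 differ in more than one place, so compound 2 and compound 3 form the first pair here in which a single change can be read. In this assay, dimethylcarbamoyl in place of cyclohexylmethyl on a saturated chain carbon, two bonds along the chain from an aromatic carbon, gives an at least 9.1-fold higher number from compound 2 to compound 3 (0.96 log units; beyond the scatter), which points to lower toxicity in this test and shows that the group at the end of this chain strongly affects the read-out. The reading for compound 3 is a limit of the assay and not a number: the limit of > 250000 nM in this assay, at which 1 of the 3 values shown sits.

From the compounds shown here alone, this single pair cannot separate the loss of the cyclohexyl ring from the arrival of the dimethylcarbamoyl group, and the full size of the step remains unknown. Going by these compounds, whether the same shift would appear with a different group at this chain end, such as a carboxylic acid, an amine or a simple methyl, or with a shorter chain carrying dimethylcarbamoyl, remains open.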